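The source may hold more compounds than are shown below. What is called first, only, known or untested is meant among the compounds shown, and "the series" means these compounds.

Measured so far in a functional assay on BMMC cells (Mus musculus, strain C57BL/6) for inhibition, with stated times of 5 days and 48 h; a higher number here means a weaker inhibitor, a lower number a stronger inhibitor:
- compound 1, `C=C1CC[C@@H]2[C@](C)(CNCc3ccc(OC)cc3)[C@H](O)CC[C@@]2(C)[C@@H]1/C=C/C1=CCOC1=O`: 750 nM
- compound 2, `C=C1CC[C@@H]2[C@](C)(CNCc3ccc(Br)cc3)[C@H](O)CC[C@@]2(C)[C@@H]1/C=C/C1=CCOC1=O`: 430 nM
- compound 3, `C=C1CC[C@H]2[C@@](C)(CC[C@@H](O)[C@@]2(C)C(=O)NCc2ccc(OC)cc2)[C@@H]1/C=C/C1=CCOC1=O`: 6530 nM

Compounds 1 and 2 share one core and differ only in the group on the aromatic ring, (bromo in place of methoxy on an aromatic carbon). This change gives a 1.7-fold lower number from compound 1 to compound 2 (0.24 log units; within the scatter), so the two numbers cannot be told apart with confidence; neither compound is called the stronger inhibitor on this evidence.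

Compound 3 carries a different core. The difference between the two cores is not broken down here. In this assay compound 3 stands at the highest of the three numbers, and its gap to compound 1 is beyond the scatter, as is its gap to compound 2. With three compounds no pattern beyond these is claimed.

Compound 4, `C=C1CC[C@H]2[C@@](C)(CC[C@@H](O)[C@@]2(C)C(=O)NCc2ccc(Br)cc2)[C@@H]1/C=C/C1=CCOC1=O`, has not yet been measured. It relates to compound 3 as compound 2 relates to compound 1: bromo in place of methoxy on an aromatic carbon. The two changes sit at the same kind of place on the ring and are the same change, made on the other core. The expectation for compound 4 rests on the pair already measured: because a 1.7-fold lower number from compound 1 to compound 2 (0.24 log units; within the scatter) lay within the scatter, the step from compound 3 to compound 4 is estimated to be of similar size, a 1.5-fold lower number from compound 3 to compound 4 (0.16 log units; within the scatter), and no larger. Compound 4 is therefore expected to give about 4500 nM in this assay, with a plausible range from 2000 nM to 10000 nM, staying well above the numbers of compounds 1 and 2.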

Compound 4, half-maximal inhibitory concentration: 3450 nM
Beside the measured number, compound 4's estimate is 1.3-fold (0.12 log units) above it, within the range that was stated.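

In this assay, bromo in place of methoxy on an aromatic carbon gives a 1.9-fold lower number from compound 3 to compound 4 (0.28 log units; within the scatter), so the two groups cannot be told apart on this core either, and the step carries from one core to the other with no difference in size that can be resolved: the same change on two cores in this assay, a 1.7-fold lower number (0.24 log units; within the scatter) from compound 1 to compound 2 and a 1.9-fold lower number (0.28 log units; within the scatter) from compound 3 to compound 4, 1.1-fold (0.04 log units) apart, within the scatter of two such steps

The gap tied to the core stays beyond the scatter in both comparisons that reach compound 4, with an 8.0-fold higher number from compound 2 to compound 4 (0.90 log units; beyond the scatter) for (4-bromobenzyl)carbamoyl in place of ((4-bromobenzyl)amino)methyl, and a 4.6-fold higher number from compound 1 to compound 4 (0.66 log units; beyond the scatter) where the group on the aromatic ring differs as well. Among the compounds shown here, this agreement shows only that the exchange of these two groups stays within the scatter on both cores; it does not rank bromo against methoxy, and with just two pairs it does not show that other changes on the aromatic ring would carry across the cores in the same way.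

The compounds shown leave open how a chloro, a nitrile or a trifluoromethyl on the same aromatic carbon would behave on either core. They also leave open whether a longer chain between the nitrogen and the aromatic ring, or a carboxylic acid in place of the carbamoyl, would change the gap between the cores.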